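The source may hold more compounds than are shown below. What is called first, only, known or untested is meant among the compounds shown, and "the series" means these compounds.

Measured compounds so far:
- Compound 1, `COc1cc(CN(C(=O)Nc2ccc(C#N)cc2)n2cnnc2)cc(OC)c1OC`, gives 21000 nM in a functional assay on B16-F10 cells (Mus musculus) for cytotoxicity, read by MTT assay, with a stated time of 48 h; on this read-out higher numbers stand for weaker inhibition and lower numbers for stronger inhibition.
- Compound 2, `CCCCCCCCCNC(=O)N(Cc1cc(OC)ccc1OC)n1cnnc1`, gives 29400 nM in this assay.

Only these two numbers exist, and they sit close together: compound 1 holds the lower of the two, but its gap to compound 2 lies within the usual scatter of the measurement, so the two cannot be told apart in rank. Going by the values given here, no pair of measured compounds differs in just one place, so no single-change step has been seen.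

Compound 3, `COc1cc(CN(C(=O)Nc2ccc(C)cc2)n2cnnc2)cc(OC)c1OC`, is the next compound to be measured. It keeps the shared core of compound 1 and differs from it in one place: methyl in place of cyano on an aromatic carbon.

Among the compounds with values here, no measured step tells what this change does here. With only the two close values of compound 1 and compound 2 to go by, the step from compound 1 to compound 3 is expected to be small, a 1.2-fold higher number from compound 1 to compound 3 (0.08 log units; within the scatter), with no direction that clearly escapes the scatter. Compound 3 is therefore estimated at 25000 nM in this assay, within a range from 10000 nM to 60000 nM.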

Compound 3, half-maximal inhibitory concentration: 46800 nM
Estimate against measurement, compound 3: 1.9-fold (0.27 log units) below; measured number inside the range.
By their numbers in this assay, from the lowest: compounds 1, 2 and 3 (each within the scatter of the next, the first and the last beyond it).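

Going by these compounds alone, the step from cyano to methyl is the first single change that can be read. In this assay, the exchange on the aromatic carbon para to a large group gives a 2.2-fold higher number from compound 1 to compound 3 (0.35 log units; beyond the scatter), a modest step, yet one that lies beyond the scatter, which the two earlier values alone could not show. This position therefore responds to a change of group, with the 4-cyanophenyl form holding the lower number of this pair and the 4-methylphenyl form the higher, while the rest of the structure stays the same. Nothing among the available data explains why the two groups differ in this way.

Within the data shown here, the single pair gives two points at one position, so it sets no trend across groups, and it remains open where an amine, a carboxylic acid, a methoxy group, a chlorine atom or a plain hydrogen at the same place would fall relative to cyano and methyl. Compound 2 differs from compound 1 and compound 3 in more than one place, so it also leaves open whether the same exchange would have a similar effect on a different framework.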